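This account rests on a few compounds, and the source may have more. Where it says the series, first, only, none or still open, it means among the compounds named here.

Compound 1 `O=C(/C=C/C1=Cc2ccccc2OC1)c1cccc(F)c1` is one of three compounds that share a core and differ only in the substituted phenyl on the carbonyl carbon. In a functional assay on the whole organism for inhibition, with Mus musculus as the target, with a stated time of 1 h, at a dose of 30 mg/kg by the intraperitoneal route (on this read-out higher numbers stand for more inhibition at the one dose given (going by the name of the read-out) and lower numbers for less inhibition), compound 1 gives 52.4%, which places it second highest of the three numbers. Compound 2 `O=C(/C=C/C1=Cc2ccccc2OC1)c1cccc(Cl)c1` gives 51%, and compound 3 `O=C(/C=C/C1=Cc2ccccc2OC1)c1ccccc1Br` gives 56.6%. The change from compound 1 to compound 2, chloro in place of fluoro on an aromatic carbon, gives a number 1.4 percentage points lower from compound 1 to compound 2 (within the scatter). Likewise a number 4.2 percentage points higher from compound 1 to compound 3 (within the scatter) and a number 5.6 percentage points higher from compound 2 to compound 3 (within the scatter) both stay within the scatter, so no exchange among these three phenyl groups has moved the read-out beyond it.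

Compound 4 `O=C(/C=C/C1=Cc2ccccc2OC1)c1cccc(Br)c1` is not yet measured. It differs from compound 1 by bromo in place of fluoro on an aromatic carbon. The step most closely related, from compound 1 to compound 2, exchanged one such group for another at the same aromatic carbon and stayed within the scatter, as did the other two steps. Compound 4 is therefore expected to show no step beyond the scatter, with a number 0.4 percentage points lower from compound 1 to compound 4 (within the scatter). The value of compound 4 is estimated at 52%, within a range of 42% to 62%.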

Compound 4, a percentage reported as inhibition, in the whole organism at one dose (the size of the read-out at that dose, not a potency): 51.7%
Compound 4: the middle estimate sits 0.3 percentage points above what was measured; the range from low to high includes it.
By their numbers in this assay, from the lowest: compounds 2, 4, 1 and 3 (each within the scatter of the next).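

In this assay a bromo at this place, meta to a large group, gives a number 0.7 percentage points lower from compound 1 to compound 4 (within the scatter) and a number 0.7 percentage points higher from compound 2 to compound 4 (within the scatter) and so fluoro, chloro and bromo on this aromatic carbon cannot be told apart. Within the data shown here, with the halogen now held the same, 3-bromophenyl in place of 2-bromophenyl on the carbonyl carbon gives a number 4.9 percentage points lower from compound 3 to compound 4 (within the scatter) and so these two placements of bromo cannot be told apart either, a comparison the earlier compounds did not offer. Nothing at hand explains why these exchanges stay within the scatter.

On these data alone, it remains open whether a group other than a halogen on this aromatic carbon, such as an amine, a methoxy group or a carboxylic acid, would move the read-out beyond the scatter. As far as these compounds go, whether a change to the shared core would do so also remains open.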